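A few compounds are considered here, and "the series" means these few. Any claim that something is new, unique, unknown or untested is made for them only; others in the source may bear on it.

Measured compounds:
compound 1 `O=C(Nc1cc(Cl)cc(Cl)c1)c1cnc(N2CCCCC2)nc1C(F)(F)F` — 5000 nM
compound 2 `O=C(Nc1cc(Cl)cc(Cl)c1)c1cncnc1C(F)(F)F` — > 10000 nM
compound 3 `O=C(Nc1cc(C(F)(F)F)cc(C(F)(F)F)c1)c1cnc(Cl)nc1C(F)(F)F` — 50 nM

In an assay on Jurkat cells for inhibition of nuclear factor NF-kappa-B p105 subunit (Homo sapiens) (on this read-out lower numbers stand for stronger inhibition and higher numbers for weaker inhibition), compound 3 gives 50 nM, the lowest of the two numbers available; compound 1 gives the other number, 5000 nM. For compound 2 only a limit was recorded, > 10000 nM, and the set includes (the limit of > 10000 nM in this assay, at which 1 of the 3 values shown sits).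

Among the compounds with values here, the only measured step, an at least 2.0-fold higher number from compound 1 to compound 2 (0.30 log units; that floor lies within the scatter), concerns the piperidin-1-yl group on the core of compound 1 and tells nothing about the outer ring that carries the two trifluoromethyl groups. Compound 4 `O=C(OC1CCCCC1)c1cc(NC(=O)c2cnc(Cl)nc2C(F)(F)F)cc(C(F)(F)F)c1` differs from compound 3 by cyclohexyloxycarbonyl in place of trifluoromethyl on an aromatic carbon. Within the data shown here, no measured pair shows what this kind of exchange does, so the expectation rests on compound 3 alone and carries a wide range. A step of a 2.0-fold higher number from compound 3 to compound 4 (0.30 log units; within the scatter) is expected, that is, none clearly beyond the usual scatter, with the larger group counted as more likely to raise than to lower the number. Compound 4 is therefore estimated at 100 nM, between 30 nM and 400 nM.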

Compound 4, half-maximal inhibitory concentration: 1800 nM
Estimate against measurement, compound 4: 18-fold (1.26 log units) below, outside the stated range (above it).
By their numbers in this assay, from the lowest: compound 3; then compound 4; then compound 1. At a limit, above all of these: compound 2.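

Putting cyclohexyloxycarbonyl in place of trifluoromethyl on this aromatic carbon gives a 36-fold higher number from compound 3 to compound 4 (1.56 log units; beyond the scatter), a large step in this assay. Within the data shown here, the earlier step concerned only a group on the core, so this is the first sign that the substituent on the outer ring, at the carbon meta to a trifluoromethyl group, strongly affects the number, and that this exchange moves it upward. Nothing measured here accounts for the size of this step.

The compounds shown leave open whether the rise follows the cyclohexane ring or the carbonyl link, which a methyl ester or a carboxylic acid on this carbon could help to separate. Also open, as far as these compounds go, is how a smaller group such as a nitrile or an amine would read at this position.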